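Cyclohexyl for 4-fluorophenyl on the sulfur side chain

The compounds below may be only part of what the source reports. "The series", "measured", "known", "first", "only" and "open" are said of these compounds alone.

Compound 1 `Cc1cc(N2CC[C@@H](C)[C@@H](N(C)c3ncnc4[nH]ccc34)C2)n2ncnc2n1`: 11300 nM
Compound 2 `Cc1cc(N2CC[C@@H](C)[C@@H](N(C)c3ncnc4[nH]ccc34)C2)n2nc(SCc3nc4ccccc4[nH]3)nc2n1`: > 100000 nM, a limit of the assay
Compound 3 `Cc1cc(N2CC[C@@H](C)[C@@H](N(C)c3ncnc4[nH]ccc34)C2)n2nc(SCc3ccc(F)cc3)nc2n1`: 26000 nM

All three results come from a functional assay on HGC-27 cells (Homo sapiens) for inhibition, read by MTT assay, with a stated time of 72 h; on this read-out higher numbers stand for weaker inhibition and lower numbers for stronger inhibition. Of the two exact numbers, the higher belongs to compound 3 at 26000 nM. The value of compound 2 is > 100000 nM, and it is a limit rather than an exact number.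

Compound 4 `Cc1cc(N2CC[C@@H](C)[C@@H](N(C)c3ncnc4[nH]ccc34)C2)n2nc(SCC3CCCCC3)nc2n1` differs from compound 3 in one group: cyclohexyl in place of 4-fluorophenyl on a saturated chain carbon bound to a sulfur. Cyclohexyl takes the place of 4-fluorophenyl on a saturated chain carbon bound to a sulfur.

Going by the values given here, three measured steps bear on this change. Adding a side chain to compound 1 raised the number both times, with a 2.3-fold higher number from compound 1 to compound 3 (0.36 log units; beyond the scatter) and an at least 8.8-fold higher number from compound 1 to compound 2 (0.94 log units; beyond the scatter). Among the compounds with values here, the closest precedent is an exchange at the same place, an at least 3.8-fold lower number from compound 2 to compound 3 (0.58 log units; beyond the scatter), where 4-fluorophenyl replaced 1H-benzimidazol-2-yl. That exchange involved a larger change of ring type, since compound 4 keeps a six-membered ring of carbon only, as compound 3 does. A small change from the 26000 nM of compound 3 therefore seems likely, with no firm direction. The expected result is a 1.2-fold higher number from compound 3 to compound 4 (0.06 log units; within the scatter), probably within the scatter. Compound 4 is estimated at 30000 nM, with an expected range of 11000 nM to 85000 nM.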

Compound 4, half-maximal inhibitory concentration: 11500 nM
For compound 4 the middle estimate is 2.6-fold (0.42 log units) above the measured one; the range from low to high includes it.
By their numbers in this assay, from the lowest: compounds 1 and 4 (each within the scatter of the next); then compound 3. At a limit, above all of these: compound 2.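

In this assay, the two six-membered rings of carbon only on the sulfur side chain are not interchangeable: cyclohexyl in place of 4-fluorophenyl gives a 2.3-fold lower number from compound 3 to compound 4 (0.35 log units; beyond the scatter). This position also turns out to tolerate a side chain with no cost in this cell read-out, since adding (cyclohexylmethyl)sulfanyl gives a 1.0-fold higher number from compound 1 to compound 4 (0.01 log units; within the scatter), which is within the scatter, whereas the other two side chains shown both raised the number. The gap to the 1H-benzimidazol-2-yl side chain is wider still, at an at least 8.6-fold lower number from compound 2 to compound 4 (0.93 log units; beyond the scatter), but that step starts from a value of compound 2 that is a limit and not a number: the limit of > 100000 nM in this assay, at which 1 of the 4 values shown sits.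

The compounds shown leave open whether any ring is needed on this chain, or whether a plain ethyl group, an amine or a carboxylic acid in its place would behave like cyclohexyl. They also leave open whether any side chain here can give a clearly lower number than compound 1 does without one. Without a side chain, compound 1 gives 11300 nM.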